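Methoxy on the fused ring of compound 1

The source may hold more compounds than are shown below. What is called first, only, known or untested is meant among the compounds shown, and "the series" means these compounds.

Measured so far in a functional assay on DU-145 cells (Homo sapiens) for cytotoxicity, read by MTT assay, with a stated time of 48 h; on this read-out lower numbers stand for stronger inhibition and higher numbers for weaker inhibition:
compound 1 `CCOC(=O)c1c(-c2cc3ccccc3oc2=O)nn(-c2ccccc2)c1C(=O)OCC` gives 57000 nM
compound 2 `CCOC(=O)c1c(-c2cc3ccccc3oc2=O)nn(-c2ccc(Cl)cc2)c1C(=O)OCC` gives 26000 nM
compound 3 `CCOC(=O)c1c(-c2cc3ccccc3oc2=O)nn(-c2ccc(Br)cc2)c1C(=O)OCC` gives 61000 nM

Compound 1 stands second highest of the three numbers. Its nearest neighbour is compound 3, which lies within the scatter of it, and its furthest is compound 2: the change a 2.2-fold lower number from compound 1 to compound 2 (0.34 log units; beyond the scatter) is modest but beyond the scatter, while a 1.1-fold higher number from compound 1 to compound 3 (0.03 log units; within the scatter) and a 2.3-fold higher number from compound 2 to compound 3 (0.37 log units; beyond the scatter) frame the same narrow spread. All three measured steps concern substitution on the phenyl attached to the pyrazole nitrogen.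

Compound 4 `CCOC(=O)c1c(-c2cc3ccc(OC)cc3oc2=O)nn(-c2ccccc2)c1C(=O)OCC` differs from compound 1 in another place: methoxy in place of hydrogen on an aromatic carbon. For the measured compounds named here, no measured step touches this ring, so nothing bears directly on the change. Going by the values given here, the measured steps on the other ring were all small, which is the only guide available, and the expected move in this assay is therefore none beyond the scatter, in either direction.

Compound 4 is estimated at 50000 nM, with a range of 20000 nM to 125000 nM; the expected step of a 1.1-fold lower number from compound 1 to compound 4 (0.06 log units; within the scatter) is small.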

Compound 4, half-maximal inhibitory concentration: 33000 nM
The estimate for compound 4 lay 1.5-fold (0.18 log units) above the measured number; the range from low to high includes it.
By their numbers in this assay, from the lowest: compounds 2, 4, 1 and 3 (each within the scatter of the next, the first and the last beyond it).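

In this assay, for the compounds shown here, the step of a 1.7-fold lower number from compound 1 to compound 4 (0.24 log units; within the scatter) gives the first reading for a change on the fused ring system, since the earlier steps all concerned the phenyl substituted in compound 2 and compound 3. It lies within the scatter, so the methoxy group of compound 4 produces no change that can be separated from repeat variation, and the substituent is tolerated in this one comparison without any resolved gain or loss. No supporting measurement is available to explain this reading.

The compounds shown leave open whether a hydroxyl, an amine, a carboxylic acid or a longer chain such as butoxy at this carbon would move the number beyond the scatter, and whether methoxy on another carbon of the same ring would read as it does here. They also leave open whether methoxy on this ring combined with the chloro group of compound 2 would give a number different from that of compound 2 alone.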